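Tertiary Amide in Place of the Ethyl Ester Tail

The source may report more compounds than this note shows. Statements on the series, on what has been measured and on what is new or still open speak of the compounds shown alone.

Compound 1 `CCCOC(=O)/C=C/c1ccc(NC(=O)C2(NC(=O)c3ccc4c(C5CCCC5)c(-c5ncc(Cl)cn5)n(C)c4c3)CCC2)cc1OCC` — > 5 h
Compound 2 `CCOc1cc(NC(=O)C2(NC(=O)c3ccc4c(C5CCCC5)c(-c5ncc(Cl)cn5)n(C)c4c3)CCC2)ccc1/C=C/C(=O)OCC(=O)OC` — 2.1 h
Compound 3 `CCOc1cc(NC(=O)C2(NC(=O)c3ccc4c(C5CCCC5)c(-c5ncc(Cl)cn5)n(C)c4c3)CCC2)ccc1/C=C/C(=O)OCC(N)=O` — 0.983 h

In an ADME assay (liver) for pharmacokinetics, with Liver microsome (Homo sapiens) as the target, using microsomes (on this read-out lower numbers stand for a shorter-lived compound and higher numbers for a longer-lived compound), compound 1 gives > 5 h, which is a limit of the assay and not a number, so for compound 1 only a limit is known (the limit of > 5 h in this assay, at which 1 of the 3 values shown sits). Compound 2 gives 2.1 h in this assay, and compound 3 gives 0.983 h. Both measured steps from compound 1 replace the same ethyl group with a carbonyl-bearing group and both read shorter: an at least 2.3-fold lower number from compound 1 to compound 2 (0.37 log units; beyond the scatter) and an at least 5.0-fold lower number from compound 1 to compound 3 (0.70 log units; beyond the scatter). Between the two carbonyl groups, a 2.1-fold lower number from compound 2 to compound 3 (0.33 log units; beyond the scatter).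

Compound 4 `CCOc1cc(NC(=O)C2(NC(=O)c3ccc4c(C5CCCC5)c(-c5ncc(Cl)cn5)n(C)c4c3)CCC2)ccc1/C=C/C(=O)OCC(=O)N(C)C(C)C` differs from compound 1 in the same place: isopropyl(methyl)carbamoyl in place of ethyl on a saturated chain carbon bound to an oxygen next to a carbonyl group. Both steps from compound 1 that bear on it went downward and beyond the scatter, so a shorter half-life than the limit for compound 1 is expected, with the tertiary amide of compound 4 judged closer to compound 2 than to compound 3. The expected step is an at least 3.1-fold lower number from compound 1 to compound 4 (0.49 log units; beyond the scatter). Compound 4 is therefore estimated at 1.6 h in this assay, within a range of 0.6 h to 4 h.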

Compound 4, half-life: 0.65 h
For compound 4 the middle estimate is 2.5-fold (0.39 log units) above the measured one; the range from low to high includes it.
By their numbers in this assay, from the lowest: compounds 4 and 3 (each within the scatter of the next); then compound 2. At a limit, above all of these: compound 1.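

In this assay, the isopropyl(methyl)carbamoyl group parts from the methoxycarbonyl group, at a 3.2-fold lower number from compound 2 to compound 4 (0.51 log units; beyond the scatter), but does not separate from the carbamoyl group, at a 1.5-fold lower number from compound 3 to compound 4 (0.18 log units; within the scatter). With an at least 7.6-fold lower number from compound 1 to compound 4 (0.88 log units; beyond the scatter), the larger amide brings no return toward the half-life of the ethyl group on a saturated chain carbon bound to an oxygen next to a carbonyl group, and replacing both amide hydrogens with isopropyl and methyl leaves the reading within the scatter of the unsubstituted carbamoyl group. The full size of the drop stays unknown, since compound 1 is known only as a limit: the limit of > 5 h in this assay, at which 1 of the 4 values shown sits.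

Going by these compounds, whether a carboxylic acid or an amine at this place would read with the amides or with the methoxycarbonyl group remains open. So does whether a longer chain carrying the amide would change the half-life.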